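Fluorine moved on the aryl ring of a triazolethione

This account rests on a few compounds, and the source may have more. Where it says the series, first, only, none or still open, it means among the compounds named here.

Compound 1 `CS(=O)(=O)c1ccc(Cc2n[nH]c(=S)n2/N=C/c2c(F)cccc2Cl)cc1`: 49.8%
Compound 2 `CS(=O)(=O)c1ccc(Cc2n[nH]c(=S)n2/N=C/c2ccc(-c3ccccc3)cc2)cc1`: 30.4%
Compound 3 `CS(=O)(=O)c1ccc(Cc2n[nH]c(=S)n2/N=C/c2ccc(F)cc2)cc1`: 2.8%

In a functional assay on HeLa cells (Homo sapiens) for cytotoxicity, read by MTT assay, with a stated time of 48 h, tested at 12.5 uM (on this read-out higher numbers stand for a stronger effect at the one concentration tested and lower numbers for a weaker effect), compound 3 gives the lowest of the three numbers. The nearest is compound 2, whose value in this assay is 30.4%, and the furthest is compound 1 with 49.8% in this assay. Compound 4 `CS(=O)(=O)c1ccc(Cc2n[nH]c(=S)n2/N=C/c2ccccc2F)cc1` differs from compound 3 only in the group on the carbon with a double bond to nitrogen: 2-fluorophenyl in place of 4-fluorophenyl on a carbon with a double bond to nitrogen.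

Among the measured compounds shown here, two measured steps bear on this change. Going from compound 1 to compound 3 the value fell: a number 47 percentage points lower from compound 1 to compound 3 (beyond the scatter), so replacing 2-chloro-6-fluorophenyl by 4-fluorophenyl cost a large amount. Going from compound 2 to compound 3 the value also fell: a number 27.6 percentage points lower from compound 2 to compound 3 (beyond the scatter). Compound 4 keeps a halogen on the ring in the manner of compound 1, yet with fluorine alone, so a step upward of modest size is expected, a number 17.2 percentage points higher from compound 3 to compound 4 (beyond the scatter). Compound 4 is therefore estimated at 20% in this assay, within a range of 2% to 45%.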

Compound 4, a percentage reported as activity, at one concentration (the size of the read-out at that concentration, not a potency): 16.5%
For compound 4 the middle estimate is 3.5 percentage points above the measured one; the range from low to high includes it.
By their numbers in this assay, from the lowest: compound 3; then compound 4; then compound 2; then compound 1.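

Swapping 4-fluorophenyl for 2-fluorophenyl leaves the atoms of the group unchanged, yet it gives a number 13.7 percentage points higher from compound 3 to compound 4 (beyond the scatter) in this assay, so the placing of a single fluorine on this ring matters on its own. Hydrogen in place of chloro on an aromatic carbon gives a step of large size, a number 33.3 percentage points lower from compound 1 to compound 4 (beyond the scatter), which shows that 2-fluorophenyl does not retain the value of the 2-chloro-6-fluorophenyl compound and that the chloro counts for more here than the shift of fluorine. Nothing available explains either step.

Going by these compounds, whether a ring bearing chloro without any fluorine would match compound 1 remains open. So does how a methoxy group or an amine on this ring would compare with the fluorine of compound 4.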